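From Methoxy to Butyl on Compound 2

A few compounds are considered here, and "the series" means these few. Any claim that something is new, unique, unknown or untested is made for them only; others in the source may bear on it.

- compound 1 `Cc1ccc(C[C@H]2C(=O)OC[C@@H]2Cc2ccccc2)cc1C`: 35000 nM
- compound 2 `COc1ccc(C[C@H]2COC[C@@H]2Cc2ccc(Cl)c(Cl)c2)cc1`: 39000 nM

Both compounds were measured in a functional assay on HL-60 cells (Homo sapiens) for cytotoxicity, read by WST assay, with a stated time of 48 h (a higher number here means that more compound is needed for the effect, a lower number that less compound is needed), and their values lie within the usual scatter of each other. On these numbers, compound 2 (39000 nM) cannot be told apart from compound 1 (35000 nM).

The next compound, compound 3 `CCCCc1ccc(C[C@H]2COC[C@@H]2Cc2ccc(Cl)c(Cl)c2)cc1`, has butyl in place of methoxy on an aromatic carbon of compound 2 (butyl in place of methoxy on an aromatic carbon). Its value is not yet known. For the measured compounds named here, no measured pair shows this change, so the data give no direct guide to the size of the step. In this assay a modest fall in the number is expected, although a result within the scatter of compound 2 would not surprise. The estimated move is a 2.4-fold lower number from compound 2 to compound 3 (0.39 log units; beyond the scatter) and no more than that. The estimate for compound 3 is 16000 nM (expected range 5000 nM to 45000 nM).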

Compound 3, half-maximal effective concentration: 23000 nM
Estimate against measurement, compound 3: 1.4-fold (0.16 log units) below; the measured number falls inside the stated range.
By their numbers in this assay, from the lowest: compounds 3, 1 and 2 (each within the scatter of the next).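

For the compounds shown here, putting butyl in place of methoxy on this aromatic carbon, para to a large group, gives a 1.7-fold lower number from compound 2 to compound 3 (0.23 log units; within the scatter) in this assay, the first direct reading of any change at this position. The exchange removes the oxygen and its hydrogen-bond acceptor and brings in a longer all-carbon chain, yet the read-out does not separate the two compounds, so this position tolerates both groups in this assay without a change that can be told from the scatter. Nothing available bears on why the two compounds read alike.

From the compounds shown here alone, whether an amine or a carboxylic acid at this position would carry the number beyond the scatter remains open. So does the effect of a chain longer than butyl, and a single step within the scatter cannot show a trend along such a series.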